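Swapping furan for thiophene in a TRPM8 agonist series

The source may report more compounds than this note shows. Statements on the series, on what has been measured and on what is new or still open speak of the compounds shown alone.

Measured in an assay on HEK293 cells for agonist activity at transient receptor potential cation channel subfamily M member 8 (Homo sapiens), read by fluorescence and calcium flux, with a stated time of 15 min; on this read-out higher numbers stand for an effect only at larger amounts of compound and lower numbers for an effect already at smaller amounts:
Compound 1 `Cc1ccc(OCC(=O)N(Cc2cccs2)c2ccn(C)n2)cc1` gives 855 nM
Compound 2 `CCN(Cc1ccoc1)C(=O)COc1ccc(C)cc1` gives 136 nM
Compound 3 `CCCc1ccc(OCC(=O)N(CC)Cc2cccs2)cc1` gives 1810 nM

All three compounds share an aryloxyacetamide core in which the amide nitrogen carries a five-membered heteroaromatic ring through a one-carbon link. Among the three numbers, compound 2 stands lowest, meaning it acts at the smallest amounts; compound 1 and compound 3 both show higher numbers, and in both cases the gap to compound 2 lies beyond the usual scatter of repeated measurements. Compound 3 shows the highest number of the three.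

The next compound, compound 4 `CCN(Cc1ccsc1)C(=O)COc1ccc(C)cc1`, keeps the ethyl group and the methylphenyl part of compound 2 and changes only the heteroaromatic ring: thiophen-3-yl in place of furan-3-yl on a saturated chain carbon bound to an amide-type nitrogen. Among the compounds with values here, no pair of measured compounds differs in just this way, so the size of this step is not established by the numbers above. Exchanging one ring atom for another of the same kind of ring is usually a gentle change, and only a small step in this assay is expected, with a modest shift toward a higher number somewhat more likely than a lower one. For compound 4 the expected value is 250 nM, with a range from 80 nM to 800 nM, which amounts to an expected step of a 1.8-fold higher number from compound 2 to compound 4 (0.26 log units; within the scatter).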

Compound 4, half-maximal effective concentration: 88 nM
Compound 4: middle estimate off by 2.8-fold (0.45 log units), on the high side; measured number inside the range.
By their numbers in this assay, from the lowest: compounds 4 and 2 (each within the scatter of the next); then compound 1; then compound 3.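

In this assay, thiophen-3-yl in place of furan-3-yl on a saturated chain carbon bound to an amide-type nitrogen gives a 1.5-fold lower number from compound 2 to compound 4 (0.19 log units; within the scatter) and so stays within the usual scatter of repeated measurements. Within the data shown here, this is the first comparison here in which only one place differs, and it shows that the oxygen-containing ring and the sulfur-containing ring cannot be told apart at this position on this read-out, at least with the ethyl group and the methylphenyl part of compound 2 held constant. No measurement at hand explains why this exchange leaves the number within the scatter.

The compounds shown leave open how far this position tolerates larger changes, such as a pyridine ring, a cyclohexyl group or a chain carrying an amine in place of the five-membered aromatic ring. They also leave open whether the same exchange would stay within the scatter if the ethyl group gave way to a butyl chain, since compound 1 and compound 3 differ from compound 2 and compound 4 in more than one place and cannot settle that.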